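Aryl swap on the saturated ring carbon: compound 4

The source may report more compounds than this note shows. Statements on the series, on what has been measured and on what is new or still open speak of the compounds shown alone.

Compound 1 `COC(=O)C1=C(C)N=C(C)/C(=C(\O)OC)C1c1cccc(Cl)c1Cl` gives 19.1 nM in a functional assay (muscle tissue) with Cavia porcellus as the target; a higher number here means that more compound is needed for the effect, a lower number that less compound is needed. Compound 2 `COC(=O)C1=C(C)N=C(C)/C(=C(\O)OC)C1c1ccccc1C#N` gives 15.9 nM, and compound 3 `COC(=O)C1=C(C)N=C(C)/C(=C(\O)OC)C1c1cccc(I)c1` gives 41.7 nM, the highest number of the three; compound 1 is its nearest neighbour, with a 2.2-fold higher number from compound 1 to compound 3 (0.34 log units; beyond the scatter), while a 2.6-fold higher number from compound 2 to compound 3 (0.42 log units; beyond the scatter) places compound 2 furthest from it. Compound 4 `COC(=O)C1=C(C)N=C(C)/C(=C(\O)OC)C1c1ccc(Br)cc1` alters the group on the saturated ring carbon: 4-bromophenyl in place of 3-iodophenyl on a saturated ring carbon. The measured steps at this position, a 2.2-fold higher number from compound 1 to compound 3 (0.34 log units; beyond the scatter) and a 2.6-fold higher number from compound 2 to compound 3 (0.42 log units; beyond the scatter), were both modest and both ran upward to compound 3; neither compares two phenyl groups that each carry a single bromine or iodine, so no direction can be read from them. A step of at most modest size is therefore expected for compound 4, a 1.1-fold lower number from compound 3 to compound 4 (0.04 log units; within the scatter). Compound 4 is estimated at 38 nM, with a range from 15 nM to 100 nM.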

Compound 4, half-maximal effective concentration: 540 nM
Compound 4: middle estimate off by 14-fold (1.15 log units), on the low side, and the stated range ends below it.
By their numbers in this assay, from the lowest: compounds 2 and 1 (each within the scatter of the next); then compound 3; then compound 4.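

Aryl groups on the saturated ring carbon are not interchangeable in this assay: the earlier swaps gave at most modest steps, whereas 4-bromophenyl gives a 13-fold higher number from compound 3 to compound 4 (1.11 log units; beyond the scatter), a 34-fold higher number from compound 2 to compound 4 (1.53 log units; beyond the scatter) and a 28-fold higher number from compound 1 to compound 4 (1.45 log units; beyond the scatter). Among the four compounds, a large step appears only with 4-bromophenyl. Nothing available accounts for the size of this step.

From the compounds shown here alone, since 3-iodophenyl and 4-bromophenyl differ in both halogen and its place on the phenyl ring, the contribution of each remains open. 3-Bromophenyl and 4-iodophenyl would separate the two, and 4-cyanophenyl would test whether a nitrile behaves like bromine there.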